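A few compounds are considered here, and "the series" means these few. Any claim that something is new, unique, unknown or untested is made for them only; others in the source may bear on it.

Within the data shown here, compound 1 `O=C(CSc1nc2ccc(NC(=O)c3ccccc3)cc2s1)NCc1ccccc1` stands at the top of the three numbers measured so far: in a functional assay on MCF7 cells (Homo sapiens) for cytotoxicity, read by MTT assay, with a stated time of 48 h (on this read-out higher numbers stand for weaker inhibition and lower numbers for stronger inhibition), compound 1 gives 35600 nM. Compound 2 `O=C(CSc1nc2ccc(NC(=O)CCl)cc2s1)NCc1ccccc1` gives 4200 nM in this assay, and compound 3 `O=C(CSc1nc2ccc(NC(=O)c3ccc(Cl)cc3)cc2s1)NCc1ccccc1` gives 25900 nM. Of the steps from compound 1, only an 8.5-fold lower number from compound 1 to compound 2 (0.93 log units; beyond the scatter) lies beyond the scatter; the step of a 1.4-fold lower number from compound 1 to compound 3 (0.14 log units; within the scatter) stays within it, and between the other two compounds a 6.2-fold higher number from compound 2 to compound 3 (0.79 log units; beyond the scatter) is again beyond it.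

Compound 4 `O=C(CSc1nc2ccc(NC(=O)c3ccccc3)cc2s1)NCc1ccc(Cl)cc1` differs from compound 1 by chloro in place of hydrogen on an aromatic carbon. Cut one bond further out the same difference reads benzyl to 4-chlorobenzyl, so the chloro enters on the benzylamino end of the molecule rather than on the amide end.

Among the measured compounds shown here, the measured step that bears on this is the one from compound 1 to compound 3, the same exchange of chloro for hydrogen on an aromatic carbon, though on a different ring: a 1.4-fold lower number from compound 1 to compound 3 (0.14 log units; within the scatter), within the scatter. The two steps that change the group on the carbonyl carbon do not speak to it. Hence no step beyond the scatter is expected in this assay, in either direction. Compound 4 is estimated at 30000 nM, with a range of 14000 nM to 65000 nM, which is an expected 1.2-fold lower number from compound 1 to compound 4 (0.07 log units; within the scatter).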

Compound 4, half-maximal inhibitory concentration: 33700 nM
Beside the measured number, compound 4's estimate is 1.1-fold (0.05 log units) below it, within the range that was stated.
By their numbers in this assay, from the lowest: compound 2; then compounds 3, 4 and 1 (each within the scatter of the next).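

In this assay the exchange of benzyl for 4-chlorobenzyl gives a 1.1-fold lower number from compound 1 to compound 4 (0.02 log units; within the scatter) and so shows that a chloro at this place on the benzylamino end leaves the number inside the scatter. With a 1.4-fold lower number from compound 1 to compound 3 (0.14 log units; within the scatter) on the amide end, chloro in place of hydrogen has now been read at both ends of the molecule, and neither exchange leaves the scatter, whereas replacing phenyl with chloromethyl on the carbonyl carbon gives an 8.5-fold lower number from compound 1 to compound 2 (0.93 log units; beyond the scatter) and remains the larger change from compound 1. Nothing measured here accounts for the absence of a step at this position.

As far as these compounds go, whether another group at this place on the benzyl ring, such as a methoxy, a carboxylic acid or an amine, would move the number remains open. Also open, from the compounds shown here alone, is whether 4-chlorobenzyl would stay within the scatter if it were placed on compound 2, where chloromethyl sits on the carbonyl carbon instead of phenyl.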